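Cyclopropyl in Place of Methyl, Made a Second Time

This account rests on a few compounds, and the source may have more. Where it says the series, first, only, none or still open, it means among the compounds named here.

Three compounds have been measured in an assay for inhibition of high affinity nerve growth factor receptor (Homo sapiens), read by HTRF, with a stated time of 30 min, in the presence of a further agent that is not named here; on this read-out lower numbers stand for stronger inhibition and higher numbers for weaker inhibition:

Compound 1, `Cc1cc(Nc2nc(NCc3ccc(F)cc3)nc3ccccc23)n[nH]1`: 20 nM
Compound 2, `Fc1ccc(CNc2nc(Nc3cc(C4CC4)[nH]n3)c3ccccc3n2)cc1`: 40 nM
Compound 3, `Cc1cc(Nc2nc(NCc3ccc(F)cc3F)nc3ccc(F)cc23)n[nH]1`: 44 nM

Compound 1 and compound 2 differ in one place only, (cyclopropyl in place of methyl on an aromatic carbon). This change gave a 2.0-fold higher number from compound 1 to compound 2 (0.30 log units; within the scatter), so the two numbers lie within the usual scatter of repeated measurements and no order between them can be claimed. Compound 3 shares the same methyl group as compound 1, but the difference between the two cores is not broken down here; compound 3 gives a number that is higher than that of compound 1 by more than the scatter, while its number and that of compound 2 lie within the scatter of each other.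

Compound 4, `Fc1ccc(CNc2nc(Nc3cc(C4CC4)[nH]n3)c3cc(F)ccc3n2)c(F)c1`, has not yet been measured. It differs from compound 3 by cyclopropyl in place of methyl on an aromatic carbon, the same change that leads from compound 1 to compound 2, made at the same place. The step from compound 3 to compound 4 is therefore expected to be about a 1.8-fold higher number from compound 3 to compound 4 (0.26 log units; within the scatter), resting on a 2.0-fold higher number from compound 1 to compound 2 (0.30 log units; within the scatter) and assuming the effect of this change does not depend on the rest of the core. For compound 4 the estimated value is 80 nM, between 35 nM and 180 nM.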

Compound 4, half-maximal inhibitory concentration: 59 nM
Compound 4: middle estimate off by 1.4-fold (0.13 log units), on the high side; the range from low to high includes it.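

In this assay, cyclopropyl in place of methyl gives a 1.3-fold higher number from compound 3 to compound 4 (0.13 log units; within the scatter), so these two compounds cannot be put in order. Set beside the earlier case, the change reads alike on the two cores, as far as this scatter allows: the same change on two cores in this assay, a 2.0-fold higher number (0.30 log units; within the scatter) from compound 1 to compound 2 and a 1.3-fold higher number (0.13 log units; within the scatter) from compound 3 to compound 4, 1.5-fold (0.17 log units) apart, within the scatter of two such steps Neither step stands clear of the scatter, however, so no real effect of the change is shown on either core, and two cores give no rule for carrying it to others.

The compounds shown carry only methyl or cyclopropyl at this place on the pyrazole, which leaves open how a larger carbon group such as tert-butyl, a phenyl ring or an amine would read in this assay. They also leave open what each fluorine that sets compound 3 apart from compound 1 contributes, as no pair shown changes one fluorine alone.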